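Vinyl to acetyl: what compound 3 may show

A few compounds are considered here, and "the series" means these few. Any claim that something is new, unique, unknown or untested is made for them only; others in the source may bear on it.

- compound 1 `COc1cc(-c2ccnc3cc(-c4cn(C)c5ccccc45)nn23)cc(OC)c1OC`: 95 nM
- compound 2 `C=Cc1ccc(-c2cc3nccc(-c4cc(OC)c(OC)c(OC)c4)n3n2)cc1`: 193 nM

Within the data shown here, in a functional assay on MCF7 cells (Homo sapiens) for inhibition, read by CCK-8 assay, with a stated time of 48 h (on this read-out higher numbers stand for weaker inhibition and lower numbers for stronger inhibition), compound 2 stands at 193 nM, the higher of the two numbers so far, which makes it the weaker inhibitor of the pair. Compound 3 `COc1cc(-c2ccnc3cc(-c4ccc(C(C)=O)cc4)nn23)cc(OC)c1OC` keeps the shared core and differs from compound 2 in one group: acetyl in place of vinyl on an aromatic carbon. Among the measured compounds shown here, only one measured step exists, a 2.0-fold higher number from compound 1 to compound 2 (0.31 log units; beyond the scatter), and it is modest. It bears only loosely, as it exchanged a whole aromatic group, whereas here only the small group on the ring changes. No measurement compares vinyl with acetyl directly, so a step no larger than that one is expected, with a slight upward lean at most. The estimated change is a 1.2-fold higher number from compound 2 to compound 3 (0.08 log units; within the scatter). For compound 3 the expected value is 230 nM, with an estimated range of 80 nM to 600 nM.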

Compound 3, half-maximal inhibitory concentration: 5230 nM
Compound 3: middle estimate off by 23-fold (1.36 log units), on the low side; measured number above the stated range.
By their numbers in this assay, from the lowest: compound 1; then compound 2; then compound 3.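

In this assay, among these compounds, the small swap of vinyl for acetyl gives a 27-fold higher number from compound 2 to compound 3 (1.43 log units; beyond the scatter) and so weakens inhibition sharply, which shows that this place on the ring tolerates far less change than the earlier compounds suggested. Exchanging the 1-methyl-1H-indol-3-yl group for 4-acetylphenyl gives a 55-fold higher number from compound 1 to compound 3 (1.74 log units; beyond the scatter) while the exchange for 4-vinylphenyl gave only a 2.0-fold higher number from compound 1 to compound 2 (0.31 log units; beyond the scatter) so the group at the far end of the phenyl ring, rather than the phenyl ring alone, decides much of the outcome here. No measurement at hand explains this loss.

On these data alone, it remains open whether the loss follows the carbonyl itself or is particular to acetyl. A hydroxyl, an ethyl or a carboxylic acid at the same place would help separate these possibilities.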